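The compounds below may be only part of what the source reports. "The series", "measured", "known", "first", "only" and "open" are said of these compounds alone.

Measured in a functional assay on HL-60 cells (Homo sapiens) for antiproliferative activity, read by MTT assay, with a stated time of 72 h; on this read-out lower numbers stand for stronger inhibition and higher numbers for weaker inhibition:
compound 1, `Cc1cc(C)cc(OCCCON2C(N)=NC(N)=NC23CCOCC3)c1`: 720 nM
compound 2, `NC1=NC2(CCSCC2)N(OCCCOc2ccccc2Br)C(N)=N1`: 180 nM

Compound 1 gives the higher of the two numbers in this assay; compound 2 sits lower, and the two differ in more than one place, so the pair shows only the two values, not a single step. Compound 3, `NC1=NC2(CCOCC2)N(OCCCOc2ccc(Br)cc2)C(N)=N1`, keeps the core of compound 1 and differs by 4-bromophenyl in place of 3,5-dimethylphenyl on an oxygen on a saturated carbon. Nothing measured isolates this change; given that the bromophenyl compound 2 gives 180 nM, a modest step to a lower number is expected, a 2.1-fold lower number from compound 1 to compound 3 (0.31 log units; beyond the scatter), though it may stay within the scatter. Compound 3 is estimated at 350 nM, range 150 nM to 900 nM.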

Compound 3, half-maximal inhibitory concentration: 310 nM
Beside the measured number, compound 3's estimate is 1.1-fold (0.05 log units) above it, within the range that was stated.
By their numbers in this assay, from the lowest: compounds 2 and 3 (each within the scatter of the next); then compound 1.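

Among these compounds, on the oxygen on a saturated carbon, 4-bromophenyl in place of 3,5-dimethylphenyl gives a 2.3-fold lower number from compound 1 to compound 3 (0.37 log units; beyond the scatter) in this assay, the first single-place comparison, and a modest step beyond the scatter. Both rings are substituted phenyls differing in substituent identity, number and placement, so the step cannot be assigned to any one of these. Nothing available accounts for the step.

Open, going by these compounds, is how an unsubstituted phenyl or a 4-methylphenyl would compare at this place. Also open, on these data alone, is whether the aromatic ring is needed at all, for instance against a cyclohexyl group or a terminal amine.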